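Pyrazole to Pyrimidine on a Urea Core

A few compounds are considered here, and "the series" means these few. Any claim that something is new, unique, unknown or untested is made for them only; others in the source may bear on it.

Within the data shown here, compound 2 `CCOC(=O)c1ccc(NC(=O)NCc2cc[nH]n2)cc1` gives 69000 nM in an assay on isolated protein for activation of Nicotinamide phosphoribosyltransferase (Homo sapiens) (a lower number here means that less compound is needed, a higher number that more compound is needed for the effect), the highest of the two numbers known here. Compound 1 `O=C(NCc1ccncc1)Nc1ccc(S(=O)(=O)Nc2ccccc2)cc1`, which differs from it in several places, gives 410 nM in this assay. Compound 3 `CCOC(=O)c1ccc(NC(=O)NCc2ccncn2)cc1` carries pyrimidin-4-yl in place of 1H-pyrazol-3-yl on a saturated chain carbon bound to an amide-type nitrogen. Among the measured compounds shown here, no measured pair shows this change on its own, so nothing here fixes its size. A modest step toward a lower number is expected, a 2.3-fold lower number from compound 2 to compound 3 (0.36 log units; beyond the scatter), though it may well stay within the scatter. For compound 3 the estimated value is 30000 nM, with a range from 6000 nM to 150000 nM.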

Compound 3, half-maximal effective concentration: 13600 nM
Beside the measured number, compound 3's estimate is 2.2-fold (0.34 log units) above it; the range from low to high includes it.
By their numbers in this assay, from the lowest: compound 1; then compound 3; then compound 2.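

Among these compounds, the pair gives the first one-place reading at this position: in this assay, pyrimidin-4-yl in place of 1H-pyrazol-3-yl gives a 5.1-fold lower number from compound 2 to compound 3 (0.71 log units; beyond the scatter), so the ring on this saturated chain carbon affects the result. The change alters ring size and hydrogen-bond donor and acceptor counts together, and this single pair cannot separate these differences. No supporting evidence bears on the step.

From the compounds shown here alone, it remains open how a phenyl or imidazolyl group would read at this place, and what a carboxylic acid in place of the ethyl ester would do.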